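The compounds below may be only part of what the source reports. "The series", "measured", "known", "first", "only" and "open" are said of these compounds alone.

In a functional assay on MCF7 cells (Homo sapiens) for cytotoxicity, read by MTT assay, with a stated time of 24 h (on this read-out lower numbers stand for stronger inhibition and higher numbers for weaker inhibition), compound 1 `c1ccc2[nH]c(SCCCN3CCNCC3)nc2c1` gives 91700 nM, compound 2 `COc1ccc(N2CCN(CCCSc3nc4ccccc4[nH]3)CC2)cc1` gives 6840 nM, and compound 3 `CCOc1ccccc1N1CCN(CCCSc2nc3ccccc3[nH]2)CC1` gives 32700 nM. Compound 3 therefore stands second highest of the three numbers: its nearest neighbour lies through a 2.8-fold lower number from compound 1 to compound 3 (0.45 log units; beyond the scatter), its furthest through a 4.8-fold higher number from compound 2 to compound 3 (0.68 log units; beyond the scatter). Compound 4 `Clc1cccc(N2CCN(CCCSc3nc4ccccc4[nH]3)CC2)c1` differs from compound 3 in one place: 3-chlorophenyl in place of 2-ethoxyphenyl on an amine nitrogen in a ring. For the measured compounds named here, no measured step exchanges one ring on that nitrogen for a 3-chlorophenyl, so the direction is uncertain; the steps that bear on it are a 13-fold lower number from compound 1 to compound 2 (1.13 log units; beyond the scatter) and a 2.8-fold lower number from compound 1 to compound 3 (0.45 log units; beyond the scatter), both lowering the number when 4-methoxyphenyl or 2-ethoxyphenyl replaces hydrogen, and a 4.8-fold higher number from compound 2 to compound 3 (0.68 log units; beyond the scatter). A modest lowering is therefore expected in this assay, a 2.2-fold lower number from compound 3 to compound 4 (0.34 log units; beyond the scatter). Compound 4 is estimated at 15000 nM, within 5000 nM to 50000 nM.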

Compound 4, half-maximal inhibitory concentration: 54600 nM
Estimate against measurement, compound 4: 3.6-fold (0.56 log units) below, outside the stated range (above it).
By their numbers in this assay, from the lowest: compound 2; then compounds 3, 4 and 1 (each within the scatter of the next, the first and the last beyond it).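

Putting 3-chlorophenyl on the amine nitrogen in place of 2-ethoxyphenyl gives a 1.7-fold higher number from compound 3 to compound 4 (0.22 log units; within the scatter), so these two groups cannot be told apart here. Against plain hydrogen the step is a 1.7-fold lower number from compound 1 to compound 4 (0.23 log units; within the scatter), so a substituted phenyl ring on this nitrogen does not by itself guarantee a clear change. Compound 2 keeps its distance, with an 8.0-fold higher number from compound 2 to compound 4 (0.90 log units; beyond the scatter), which leaves 4-methoxyphenyl as the group that stands out. No measurement at hand explains this result. From the compounds shown here alone, it remains open whether 3-methoxyphenyl or 4-chlorophenyl on that nitrogen would match 4-methoxyphenyl, which would separate the choice of group from where it sits on the phenyl ring.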